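Propargyl to Benzyl: Expected Shift for Compound 4

The source may report more compounds than this note shows. Statements on the series, on what has been measured and on what is new or still open speak of the compounds shown alone.

Four carbamates are compared in an assay on BTI-TN-5B1-4 cells for inhibition of Amine oxidase [flavin-containing] B (Homo sapiens), read by fluorescence and Amplex Red, using microsomes, with a stated time of 15 min; a lower number here means a stronger inhibitor, a higher number a weaker inhibitor. Compound 1 `C#CCN1CCCC(OC(=O)Nc2ccccc2)C1` carries the propargyl group. In this assay compound 1 reports only a limit, > 100000 nM, which is the limit of > 100000 nM in this assay, at which 1 of the 3 values shown sits. Compound 2 `O=C(Nc1ccccc1)OC1CCCN(Cc2ccccc2)C1` gives 33300 nM in this assay. The change phenyl in place of ethynyl on a saturated chain carbon bound to an amine nitrogen in a ring produced an at least 3.0-fold lower number from compound 1 to compound 2 (0.47 log units; beyond the scatter). Compound 3 `C#CCN1CCC(OC(=O)Nc2ccc(C(C)C)cc2)CC1` gives 178 nM in this assay, the lower of the two numbers reported; the difference between the core of compound 1 and the core of compound 3 is not broken down here. Compound 4 `CC(C)c1ccc(NC(=O)OC2CCN(Cc3ccccc3)CC2)cc1` differs from compound 3 by phenyl in place of ethynyl on a saturated chain carbon bound to an amine nitrogen in a ring, the same change as made earlier in the series. On these data alone, that earlier step, an at least 3.0-fold lower number from compound 1 to compound 2 (0.47 log units; beyond the scatter), started from a limit, so its full size is unknown. For compound 4 a modest lowering is expected, estimated as a 2.0-fold lower number from compound 3 to compound 4 (0.30 log units; within the scatter). Compound 4 is expected at 90 nM in this assay, between 25 nM and 350 nM.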

Compound 4, half-maximal inhibitory concentration: > 100000 nM
Compound 4 gave a limit, no number; the forecaster's own chance of this, stated with the estimate: 2%; middle value at least 1100-fold (3.04 log units) from the limit.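

In this assay, propargyl to benzyl on the core of compound 3 gives an at least 560-fold higher number from compound 3 to compound 4 (2.74 log units; beyond the scatter), opposite in direction to the earlier step. The change therefore does not carry over between these two cores: the same change on two cores in this assay, an at least 3.0-fold lower number (0.47 log units; beyond the scatter) from compound 1 to compound 2 and an at least 560-fold higher number (2.74 log units; beyond the scatter) from compound 3 to compound 4, at least 1600-fold (3.22 log units) apart, beyond the scatter of two such steps
The difference between the two cores is not broken down, so the part of it tied to the reversal is not shown, and neither step has a known full size, with compound 1 and compound 4 both resting on a limit: the limit of > 100000 nM in this assay, at which 2 of the 4 values shown sit.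

Left open is how a methyl or a longer chain ending in ethynyl, in place of propargyl or benzyl, would read on either core. Also open, on these data alone, is whether a benzyl carrying a fluorine or a methoxy group would read like benzyl itself.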